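This account rests on a few compounds, and the source may have more. Where it says the series, first, only, none or still open, it means among the compounds named here.

In a physicochemical assay for lipophilicity, at pH 7.4 (a higher number here means a more lipophilic compound, a lower number a more polar compound), compound 1 `CCCn1nc2c(=O)[nH]c(-c3cc(S(=O)(=O)N4CCN(CC)CC4)cnc3OCCOC)nc2c1CC` gives 1 with propyl and compound 2 `CCc1c2nc(-c3cc(S(=O)(=O)N4CCN(CC)CC4)cnc3OCCOC)[nH]c(=O)c2nn1C(C)C` gives 1 with isopropyl, so compound 2 stands level with compound 1. Compound 3 `CCc1c2nc(-c3cc(S(=O)(=O)N4CCN(CC)CC4)cnc3OCCOC)[nH]c(=O)c2nn1C1CCC1` carries cyclobutyl in place of isopropyl on an aromatic nitrogen. Among the compounds with values here, the only measured step at this place, isopropyl in place of propyl, shows no change at the digits printed from compound 1 to compound 2 (within the scatter) and involves no ring, so it is only a loose guide. The expected step in this assay is small and upward (a number 0.20 log units higher from compound 2 to compound 3 (within the scatter)) and may not clear the scatter. Compound 3 is estimated at 1.2 with an expected range from 0.8 to 1.7 on this scale.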

Compound 3, distribution coefficient: 1
Estimate against measurement, compound 3: 0.20 log units above; low and high end bracket the measured number.
By their numbers in this assay, from the lowest: compounds 1, 2 and 3 (each within the scatter of the next).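

Cyclobutyl in place of isopropyl on an aromatic nitrogen gives no change at the digits printed from compound 2 to compound 3 (within the scatter) in this assay and cyclobutyl in place of propyl gives no change at the digits printed from compound 1 to compound 3 (within the scatter) in the same read-out. This position therefore now includes a group with a four-membered non-aromatic ring alongside the two open chains, with no step beyond the scatter. No available data bear on why these groups read alike.

All three groups here contain carbon only. From the compounds shown here alone, whether an amine, a carboxylic acid or a longer chain at this position would read the same remains open.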